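Adding a Propyl Branch to the Acid Chain

The compounds below may be only part of what the source reports. "The series", "measured", "known", "first", "only" and "open" are said of these compounds alone.

Compound 2 `O=C(O)CCCCc1cccc(OCc2ccc3ccccc3n2)c1` gives 100 nM in an assay on membranes from lung (Cavia porcellus) for binding affinity to cysteinyl leukotriene receptor (Homo sapiens); on this read-out higher numbers stand for weaker inhibition and lower numbers for stronger inhibition. Of the two numbers measured it stands at the top, yet within the scatter of compound 1 `CC(CCCC(=O)O)c1cccc(OCc2ccc3ccccc3n2)c1`, which gives 90 nM. Among the compounds with values here, the single measured step, a 1.1-fold higher number from compound 1 to compound 2 (0.05 log units; within the scatter), exchanged a methyl for hydrogen on a saturated chain carbon bound to an aromatic carbon and left the number essentially unchanged. Compound 3 `CCCC(CCC(=O)O)Cc1cccc(OCc2ccc3ccccc3n2)c1` differs from compound 2 by propyl in place of hydrogen on a saturated chain carbon bound to two saturated chain carbons, a larger group placed on a chain carbon bound to two saturated chain carbons rather than one bound to an aromatic carbon, so that step bears on it only loosely, suggesting that branching on this chain has so far shifted the numbers little. The expected step for compound 3 is therefore a 1.2-fold higher number from compound 2 to compound 3 (0.08 log units; within the scatter), not beyond the scatter. Compound 3 is estimated at 120 nM, ranging from 40 nM to 400 nM.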

Compound 3, inhibition constant: 50 nM
Compound 3: the middle estimate sits 2.4-fold (0.38 log units) above what was measured; the measured number falls inside the stated range.
By their numbers in this assay, from the lowest: compounds 3, 1 and 2 (each within the scatter of the next).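

Until now the only branch on the acid chain was a methyl on a saturated chain carbon bound to an aromatic carbon. Propyl now sits on a saturated chain carbon bound to two saturated chain carbons, and in this assay the change gives a 2.0-fold lower number from compound 2 to compound 3 (0.30 log units; within the scatter) so this larger branch at this other place also leaves the number within the scatter of the unbranched compound 2. No measurement here explains this result.

Going by these compounds, whether a methyl or a butyl on this same carbon would also stay within the scatter of compound 2 remains open. So does the outcome with a hydroxyl group or an amine there, since propyl is the only group shown at this place.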